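The compounds below may be only part of what the source reports. "The series", "measured", "known", "first", "only" and "open" are said of these compounds alone.

Compound 1 `COC(=O)CCCNC(=O)CSC1=C(OC)C(=O)c2ccccc2C1=O` is one of two compounds tested in a functional assay on HeLa cells (Homo sapiens) for cytotoxicity, read by MTT assay, with a stated time of 48 h; a lower number here means a stronger inhibitor, a higher number a weaker inhibitor. In this assay, for the measured compounds named here, compound 1 gives 24000 nM, the only number recorded. Compound 2 `COC(=O)[C@H](CC(C)C)NC(=O)CSC1=C(C)C(=O)c2cccc(OC)c2C1=O` returned a limit of the assay, > 100000 nM, in this assay. The move to compound 3 `COC(=O)[C@@H](NC(=O)CSC1=C(OC)C(=O)c2ccccc2C1=O)C(C)C` changes the side chain on the amide: 1-(methoxycarbonyl)-2-methylpropyl in place of 3-(methoxycarbonyl)propyl on an amide-type nitrogen. Going by the values given here, no measured pair shows the effect of such a change. Because one of the two recorded values sits at the limit of > 100000 nM in this assay, at which 1 of the 2 values shown sits, a somewhat weaker result is expected for compound 3, with the step of a 1.7-fold higher number from compound 1 to compound 3 (0.22 log units; within the scatter) expected to be modest. Compound 3 is expected to give 40000 nM, between 12000 nM and 150000 nM.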

Compound 3, half-maximal inhibitory concentration: 93500 nM
Estimate against measurement, compound 3: 2.3-fold (0.37 log units) below, and the stated range covers the measured number.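

On the amide-type nitrogen, 1-(methoxycarbonyl)-2-methylpropyl in place of 3-(methoxycarbonyl)propyl gives a 3.9-fold higher number from compound 1 to compound 3 (0.59 log units; beyond the scatter) in this assay and so offers the first measured sign that this side chain affects the result. On this shared core, the change weakens cytotoxicity. Compound 3 leaves little room for ranking still weaker compounds: the limit of > 100000 nM in this assay, at which 1 of the 3 values shown sits.

A single step cannot separate the effect of the branched chain from that of its defined stereocentre. As far as these compounds go, whether an amine, a longer chain, or a carboxylic acid in place of the methoxycarbonyl group would give a lower number remains open.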